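The compounds below may be only part of what the source reports. "The series", "measured", "known", "first", "only" and "open" are said of these compounds alone.

The three measured compounds share one core and differ only in the group carried on a saturated chain carbon bound to an aromatic carbon. Compound 1 `O=c1cc(-n2cc(CNc3ccccc3)nn2)c2cc(Br)ccc2o1` carries an anilino group there; in a functional assay on MCF7 cells (Homo sapiens) for antiproliferative activity, read by MTT assay, with a stated time of 48 h (a lower number here means a stronger inhibitor, a higher number a weaker inhibitor), compound 1 gives > 50000 nM, which is a limit of the assay and not a number. Compound 2 `O=c1cc(-n2cc(COc3ccccc3O)nn2)c2cc(Br)ccc2o1` carries a 2-hydroxyphenoxy group, and in this assay compound 2 gives 24800 nM. Compound 3 `CCc1ccc(OCc2cn(-c3cc(=O)oc4ccc(Br)cc34)nn2)cc1` carries a 4-ethylphenoxy group, and compound 3 gives 12700 nM, the lowest of the two plain numbers shown, though the step of a 2.0-fold lower number from compound 2 to compound 3 (0.29 log units; within the scatter) is small. The other two steps, an at least 2.0-fold lower number from compound 1 to compound 2 (0.30 log units; that floor lies within the scatter) and an at least 3.9-fold lower number from compound 1 to compound 3 (0.59 log units; beyond the scatter), each start from a limit (the limit of > 50000 nM in this assay, at which 1 of the 3 values shown sits).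

Compound 4 `O=c1cc(-n2cc(COc3ccc(Br)cc3)nn2)c2cc(Br)ccc2o1` differs from compound 3 by bromo in place of ethyl on an aromatic carbon, sitting on an aromatic carbon of a six-membered aromatic ring of carbon only, para to a large group. Within the data shown here, of the measured steps, only the one from compound 2 to compound 3 alters the substituent on that phenoxy ring, and it was small. One therefore expects in this assay a step of a 1.3-fold higher number from compound 3 to compound 4 (0.10 log units; within the scatter), not beyond the scatter. Compound 4 is estimated at 16000 nM, with a range from 6000 nM to 45000 nM.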

Compound 4, half-maximal inhibitory concentration: 1920 nM
For compound 4 the middle estimate is 8.3-fold (0.92 log units) above the measured one; the whole stated range lies above it.
By their numbers in this assay, from the lowest: compound 4; then compounds 3 and 2 (each within the scatter of the next). At a limit, above all of these: compound 1.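

In this assay, the group on an aromatic carbon of the six-membered aromatic ring of carbon only, para to a large group, proves able to move the number well beyond the scatter: bromo in place of ethyl gives a 6.6-fold lower number from compound 3 to compound 4 (0.82 log units; beyond the scatter), whereas the earlier step between the two phenoxy compounds stayed within it. Set against the 2-hydroxyphenoxy group, the 4-bromophenoxy group gives a 13-fold lower number from compound 2 to compound 4 (1.11 log units; beyond the scatter), so the close values of the earlier pair did not mark the lowest number that this part of the series can reach. Compound 1 stands at a limit and not at a number, so an at least 26-fold lower number from compound 1 to compound 4 (1.41 log units; beyond the scatter) can be read only as a floor: the limit of > 50000 nM in this assay, at which 1 of the 4 values shown sits.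

The compounds shown leave open whether chloro, methoxy or a carboxylic acid in the same place would give a number near that of compound 4, and whether bromo would keep its effect on another carbon of that ring. They also hold no measurement that tells why bromo and ethyl differ here, so the step stands as an observation without a cause.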